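Methoxy on the phenyl ring: what to expect

The source may hold more compounds than are shown below. What is called first, only, known or untested is meant among the compounds shown, and "the series" means these compounds.

Compound 1 `O=C(Nc1ccc(Oc2ccnc3[nH]ccc23)cc1)c1cc2cccnc2n(-c2ccccc2)c1=O` and compound 2 `O=C(Nc1ccc(Oc2ccnc3[nH]ccc23)c(F)c1)c1cc2cccnc2n(-c2ccccc2)c1=O` share a core and differ only by a fluorine. In a functional assay on HT-29 cells (Homo sapiens) for antiproliferative activity, read by MTT assay, with a stated time of 72 h (on this read-out lower numbers stand for stronger inhibition and higher numbers for weaker inhibition), compound 1 gives 290 nM, and compound 2 gives 160 nM; the step of a 1.8-fold lower number from compound 1 to compound 2 (0.26 log units; within the scatter) falls within the scatter. Compound 2 thus holds the lowest of the two numbers shown, without standing apart from compound 1. Compound 3 `COc1ccc(-n2c(=O)c(C(=O)Nc3ccc(Oc4ccnc5[nH]ccc45)c(F)c3)cc3cccnc32)cc1` carries methoxy in place of hydrogen on an aromatic carbon; the same difference, seen one bond further out, reads phenyl to 4-methoxyphenyl. Going by the values given here, no measured step touches this ring, so no step beyond the scatter is expected, a 1.1-fold higher number from compound 2 to compound 3 (0.03 log units; within the scatter). Compound 3 is expected at 170 nM, between 60 nM and 480 nM.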

Compound 3, half-maximal inhibitory concentration: 540 nM
Beside the measured number, compound 3's estimate is 3.2-fold (0.50 log units) below it, and the stated range ends below it.
By their numbers in this assay, from the lowest: compounds 2, 1 and 3 (each within the scatter of the next, the first and the last beyond it).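

Going by these compounds alone, this is the first measured change on this phenyl ring, and it shows that the ring does not tolerate every substitution without effect. In this assay, methoxy in place of hydrogen, on an aromatic carbon para to a large group, gives a 3.4-fold higher number from compound 2 to compound 3 (0.53 log units; beyond the scatter), a modest weakening beyond the scatter. The data offer no measured explanation for this weakening. One substituent cannot show whether the weakening belongs to methoxy alone or extends to other groups at this position. An amine, a carboxylic acid or a longer chain such as butoxy could read differently.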